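The source may hold more compounds than are shown below. What is called first, only, known or untested is meant among the compounds shown, and "the series" means these compounds.

Measured compounds:
compound 1, `Fc1ccc(/C=N/Nc2nc(-c3ccc(C(F)(F)F)cc3)cs2)cc1F`: 79500 nM
compound 2, `Fc1ccc(/C=N/Nc2nc(-c3ccccc3)cs2)cc1F`: > 100000 nM
compound 3, `COc1cc(/C=N/Nc2nc(-c3ccc(C(F)(F)F)cc3)cs2)cc(Br)c1OC`: > 100000 nM

Of the compounds shown here, three from this series have been tested in an ADME assay on HUVEC cells (Homo sapiens) for inhibition, read by MTT assay, with a stated time of 48 h; a higher number here means a weaker inhibitor, a lower number a stronger inhibitor. Compound 1 gives 79500 nM in this assay. For compound 2 the reported value of > 100000 nM is a limit of the assay and not a number. The same holds for compound 3, whose > 100000 nM is also a limit. Two of the three values thus sit at the limit of > 100000 nM in this assay, at which 2 of the 3 values shown sit.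

Compound 2 differs from compound 1 by one change, (hydrogen in place of trifluoromethyl on an aromatic carbon). The step that this change made is an at least 1.2-fold higher number from compound 1 to compound 2 (0.09 log units; that floor lies within the scatter). Compound 4, `COc1cc(/C=N/Nc2nc(-c3ccccc3)cs2)cc(Br)c1OC`, has not yet been measured in this assay. It differs from compound 3 by the same kind of change, (hydrogen in place of trifluoromethyl on an aromatic carbon). How the core of compound 3 differs from the core of compound 1 is not broken down here.

Since compound 3 already stands at a limit in this assay, and the earlier step of an at least 1.2-fold higher number from compound 1 to compound 2 (0.09 log units; that floor lies within the scatter) did not make the number lower, compound 4 is expected to stand at or beyond that limit as well, an expected step that the limit leaves unreadable from compound 3 to compound 4. The estimate for compound 4 in this assay is 150000 nM, with an expected range from 80000 nM to 400000 nM; most likely the assay will again report only a limit for compound 4.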

Compound 4, half-maximal inhibitory concentration: > 100000 nM
Compound 4 ended at the assay's limit; the forecaster's own chance of this, stated with the estimate: 85%; the middle value is on the limit's open side.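

In this assay compound 4 gives > 100000 nM, a limit and not a number. For the compounds shown here, compound 3 gives > 100000 nM, also a limit, so no step from compound 3 to compound 4 can be read. The compounds shown leave open what hydrogen in place of trifluoromethyl does on the core of compound 3, and how compound 2, compound 3 and compound 4 compare, as most values share one limit: the limit of > 100000 nM in this assay, at which 3 of the 4 values shown sit.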